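Halogenated aryl variants on the benzimidazole-piperidine series

The compounds below may be only part of what the source reports. "The series", "measured", "known", "first", "only" and "open" are said of these compounds alone.

Compound 2 `COc1ccc(-c2nc3ccccc3n2CCCN2CCC(c3cccc(NC(C)=O)c3)CC2)cc1` gives 9 nM in an assay for displacement of a labelled ligand from melanin-concentrating hormone receptor 1 (Homo sapiens), read by fluorescence; a higher number here means a weaker inhibitor, a lower number a stronger inhibitor. For the measured compounds named here, it stands second highest of the three numbers so far: compound 3 `CC(=O)Nc1cccc(C2CCN(CCCn3c(-c4ccc(Br)cc4)nc4ccccc43)CC2)c1` gives 5 nM, and compound 1 `CC(=O)Nc1cccc(C2CCN(CCn3c(-c4ccccc4)nc4ccccc43)CC2)c1` gives 10000 nM. Compound 4 `CC(=O)Nc1cccc(C2CCN(CCCn3c(-c4ccc(Cl)cc4F)nc4ccccc43)CC2)c1` is not yet measured; it differs from compound 2 by 4-chloro-2-fluorophenyl in place of 4-methoxyphenyl on an aromatic carbon. Going by the values given here, the one measured step that bears on this exchange of the aryl substituent is a 1.8-fold lower number from compound 2 to compound 3 (0.26 log units; within the scatter), where a halogen replaced the methoxy on the same aromatic position. Compounds 1 and 2 differ at more than one place, so their values do not isolate this change. A step of no more than the scatter is therefore expected, a 1.3-fold lower number from compound 2 to compound 4 (0.11 log units; within the scatter). Compound 4 is estimated at 7 nM, with a range from 3 nM to 20 nM.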

Compound 4, half-maximal inhibitory concentration: 1 nM
Beside the measured number, compound 4's estimate is 7.0-fold (0.85 log units) above it, outside the stated range (below it).
By their numbers in this assay, from the lowest: compound 4; then compounds 3 and 2 (each within the scatter of the next); then compound 1.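

At this aromatic carbon between two ring nitrogen atoms, the aryl group now registers in this assay: 4-chloro-2-fluorophenyl gives a 9.0-fold lower number from compound 2 to compound 4 (0.95 log units; beyond the scatter) and a 5.0-fold lower number from compound 3 to compound 4 (0.70 log units; beyond the scatter), both beyond the scatter, whereas bromo in place of methoxy stayed within it (a 1.8-fold lower number from compound 2 to compound 3 (0.26 log units; within the scatter)). The position therefore responds to the aryl substitution, and a single para-free reading of halogen exchange alone no longer describes it. No measurement in hand accounts for this gain. The compounds shown do not separate the contribution of the chloro group from that of the fluoro group. Going by these compounds, how an amine or a carboxylic acid on this aryl ring would read also remains open.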